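The compounds below may be only part of what the source reports. "The series", "measured", "known", "first", "only" and "open" are said of these compounds alone.

Measured compounds:
Compound 1, `C=C=CCN(C)Cc1ccccc1`, gives 8200 nM in an assay on isolated protein for inhibition of Monoamine oxidase (Rattus norvegicus); a lower number here means a stronger inhibitor, a higher number a weaker inhibitor.
Compound 2, `C=C=C(CN)Cc1ccccc1`, gives 20000 nM in this assay.
Compound 3, `C=C=C(CNC)Cc1ccccc1`, gives 6200 nM in this assay.

Compound 1 and compound 3 are built from the same atoms joined differently; the difference between the two cores is not broken down here. Compound 1 and compound 3 lie within the scatter of each other, while compound 2 shows a higher number than either.

One change is seen once among the measured pairs. From compound 3 to compound 2 the change is hydrogen in place of methyl on an amine nitrogen, and it made a 3.2-fold higher number from compound 3 to compound 2 (0.51 log units; beyond the scatter).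

Compound 4, `C=C=CCNCc1ccccc1`, is not yet measured. From compound 1 to compound 4 the change is hydrogen in place of methyl on an amine nitrogen. The place differs: in compound 3 the amine nitrogen has one other neighbour, a saturated chain carbon, whereas in compound 1 it has two, both saturated chain carbons. So this is the same kind of change, not the same change. The step from compound 1 to compound 4 is expected to be a 2.7-fold higher number from compound 1 to compound 4 (0.43 log units; beyond the scatter), which rests on the step of a 3.2-fold higher number from compound 3 to compound 2 (0.51 log units; beyond the scatter) seen in the measured pair. Compound 4 is therefore estimated at 22000 nM, within the range 9000 nM to 55000 nM.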

Compound 4, half-maximal inhibitory concentration: 1800 nM
Beside the measured number, compound 4's estimate is 12-fold (1.09 log units) above it, outside the stated range (below it).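

In this assay putting hydrogen in place of methyl on the amine nitrogen gave a 4.6-fold lower number from compound 1 to compound 4 (0.66 log units; beyond the scatter) and so a stronger inhibitor on this core. Two pairs show that the size and even the direction of this change cannot simply be carried from one core to another in this series, but they do not show which difference between the cores matters or why. The same change moved the number in opposite directions on the two cores, and the gap between the two steps is larger than repeated measurements would explain: the same change on two cores in this assay, a 3.2-fold higher number (0.51 log units; beyond the scatter) from compound 3 to compound 2 and a 4.6-fold lower number (0.66 log units; beyond the scatter) from compound 1 to compound 4, 15-fold (1.17 log units) apart, beyond the scatter of two such steps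

The compounds shown leave open what an ethyl group or a longer chain on the amine nitrogen would do on each core, and whether such a group would also move the number in opposite directions. On these data alone, it also remains open whether the same change on a further core would follow the step seen on the core of compound 1 or the one seen on the core of compound 3.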